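Series notes: shortening the alkyl chain of compound 3

A few compounds are considered here, and "the series" means these few. Any claim that something is new, unique, unknown or untested is made for them only; others in the source may bear on it.

Three compounds sharing one core have numbers in a functional assay on OVCAR-3 cells (Homo sapiens) for antiproliferative activity, read by WST assay, with a stated time of 72 h; a higher number here means a weaker inhibitor, a lower number a stronger inhibitor. Compound 1 `CCCCCCCCCCCCCCCCCC/N=c1\nc(N)c2nc[nH]c2c(N)n1` gives 3100 nM. Compound 2 `Nc1n/c(=N\CCCCc2ccccc2)nc(N)c2c1ncn2Cc1ccccc1` gives 37300 nM. Compound 3 `CCCCCCCCCCCCCCCCCC/N=c1\nc(N)c2ncn(Cc3ccccc3)c2c(N)n1` gives 4950 nM. Going by the values given here, the only single-point step measured is a 1.6-fold higher number from compound 1 to compound 3 (0.20 log units; within the scatter). Among the compounds with values here, compound 3 thus stands second highest of the three numbers; its nearest neighbour is compound 1, within the scatter, and its furthest is compound 2, whose number lies beyond the scatter from that of compound 3, though these two structures differ in more than one place and no single step links them.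

Compound 4 `CCCCCCCCCCCCCC/N=c1\nc(N)c2ncn(Cc3ccccc3)c2c(N)n1` is the next compound for this assay. It differs from compound 3 by hydrogen in place of butyl on a saturated chain carbon, ten or more bonds along the chain from a double-bonded nitrogen. Within the data shown here, no measured step shortens or lengthens this chain while holding the rest constant, so there is no direct precedent; the one step available, benzyl for hydrogen on the aromatic nitrogen, touches a different part of the molecule and stays within the scatter. The comparison of compound 2 with compound 3 involves a shorter chain together with other changes and shows a weaker number for compound 2. For compound 4 a modest move toward a higher number is therefore expected, a 1.4-fold higher number from compound 3 to compound 4 (0.15 log units; within the scatter), though a result within the scatter would not be surprising. Compound 4 is estimated at 7000 nM in this assay, with an expected range from 2500 nM to 20000 nM.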

Compound 4, half-maximal inhibitory concentration: 5500 nM
For compound 4 the middle estimate is 1.3-fold (0.10 log units) above the measured one, within the range that was stated.
By their numbers in this assay, from the lowest: compounds 1, 3 and 4 (each within the scatter of the next); then compound 2.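

In this assay, hydrogen in place of butyl on a saturated chain carbon, ten or more bonds along the chain from a double-bonded nitrogen, gives a 1.1-fold higher number from compound 3 to compound 4 (0.05 log units; within the scatter), so at this position the loss of those four carbons leaves the number within the scatter for this pair. The chain change at four bonds from the double-bonded nitrogen reads differently: decyl in place of phenyl gives a 6.8-fold lower number from compound 2 to compound 4 (0.83 log units; beyond the scatter), which now ties compound 2 to the long-chain compounds through a single step beyond the scatter. No measured evidence accounts for either step.

The step from compound 2 swaps a phenyl ring for a decyl chain, so it cannot separate the presence of the ring from the length of the chain, and the shared core with a plain hexyl or octyl chain would be needed to show where along the series the number begins to move. Equally open, from the compounds shown here alone, is whether a chain ending in an amine or a carboxylic acid would behave as the plain alkyl chains of compound 3 and compound 4 do.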